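Triazole ester series: furan-3-yl against cyclohexyl

The source may hold more compounds than are shown below. What is called first, only, known or untested is meant among the compounds shown, and "the series" means these compounds.

Measured compounds in a functional assay on Jurkat cells (Homo sapiens) for inhibition, read by MTT assay, with a stated time of 72 h; on this read-out lower numbers stand for stronger inhibition of growth and higher numbers for weaker inhibition of growth:
compound 1, `COC(=O)c1nc(-c2ccoc2)n(-c2ccc(F)cc2)n1`, 9320 nM
compound 2, `COC(=O)c1nc(C2CCCCC2)n(-c2ccc(C(F)(F)F)cc2)n1`, gives only a limit, > 100000 nM

Compound 2 stands at the limit of this assay, so for compound 2 only a boundary and no number is known (the limit of > 100000 nM in this assay, at which 1 of the 2 values shown sits). Going by the values given here, compound 1 and compound 2 differ in more than one place, so the two values give no single step between them; they show only that compound 1 has a number in this assay and compound 2 does not.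

Compound 3, `COC(=O)c1nc(-c2ccoc2)n(-c2ccc(C(F)(F)F)cc2)n1`, has not yet been measured. It keeps everything of compound 2 except one change: furan-3-yl in place of cyclohexyl on an aromatic carbon. Among the compounds with values here, no measured pair shows this change on its own.

For compound 3 the expected value in this assay is 25000 nM, with a range from 6000 nM to 100000 nM. Such an estimate means an expected step of an at least 4.0-fold lower number from compound 2 to compound 3 (0.60 log units; beyond the scatter), a move away from the limit toward a measurable number, though the true size of that step cannot be fixed while compound 2 remains only a limit.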

Compound 3, concentration for 50% growth inhibition: 97200 nM
Beside the measured number, compound 3's estimate is 3.9-fold (0.59 log units) below it, and the stated range covers the measured number.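

In this assay, going by these compounds alone, the furan-3-yl for cyclohexyl change on the aromatic carbon of the triazole can now be read with trifluoromethyl held constant, and it gives an at least 1.0-fold lower number from compound 2 to compound 3 (0.01 log units; that floor lies within the scatter), so the data show no step at this position beyond the scatter. Compound 2 remains a limit and not a number, which makes that step only a floor whose true size stays unknown: the limit of > 100000 nM in this assay, at which 1 of the 3 values shown sits.

With furan-3-yl held constant, the other change gives a clear result, a 10-fold higher number from compound 1 to compound 3 (1.02 log units; beyond the scatter), for trifluoromethyl in place of fluoro on an aromatic carbon, so within this pair the larger measured shift comes from that change and not from the one at the triazole carbon.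

The compounds shown leave open how cyclohexyl behaves with fluoro in place of trifluoromethyl, and so whether the furan-3-yl for cyclohexyl change would have a readable size against that background. They also leave open what a carboxylic acid in place of the methoxycarbonyl group, or an amine in place of furan-3-yl, would do to growth inhibition in this assay.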